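Methyl on the ring: compound 3 to compound 4

This account rests on a few compounds, and the source may have more. Where it says the series, first, only, none or still open, it means among the compounds named here.

Measured so far in a functional assay on MCF7 cells (Homo sapiens) for cytotoxicity, read by MTT assay, with a stated time of 72 h, tested at 100 uM; on this read-out lower numbers stand for less inhibition of growth and higher numbers for more inhibition of growth at the one concentration tested:
compound 1 `Cc1ccnc(/C(N)=N/NC(=S)N2CCSCC2)c1` gives 76.8%
compound 2 `N/C(=N\NC(=S)N1CCCCC1)c1ccccn1` gives 77.7%
compound 3 `N/C(=N\NC(=S)N1CCCC1)c1ccccn1` gives 74.9%

Compound 3 holds the lowest of the three numbers, yet its gaps to the other two stay within the scatter, so no order among the three can be claimed. Among the measured compounds shown here, the one single-point step measured, a number 2.8 percentage points lower from compound 2 to compound 3 (within the scatter), concerns the amine ring on the thiocarbonyl carbon and is itself within the scatter.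

Compound 4 `Cc1ccnc(/C(N)=N/NC(=S)N2CCCC2)c1` is the next compound, and it differs from compound 3 by methyl in place of hydrogen on an aromatic carbon. For the measured compounds named here, no measured pair differs only in this way: compound 1 carries the methyl on its ring and compound 2 does not, but the two also differ in the amine ring. Compound 1 gives 76.8% and compound 2 gives 77.7%, and these two values show only that both lie close to compound 3. Every change recorded in this set has left this assay essentially unmoved, and nothing among the shown compounds points to a different outcome here. Compound 4 is therefore expected to sit near compound 3, with a step of a number 1.1 percentage points higher from compound 3 to compound 4 (within the scatter) that is not expected to exceed the scatter. The estimate for compound 4 is 76%, between 66% and 86%.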

Compound 4, percent growth inhibition at one concentration: 87.7%
Compound 4: middle estimate off by 11.7 percentage points, on the low side; the measured number lies above the stated range.
By their numbers in this assay, from the lowest: compounds 3, 1, 2 and 4 (each within the scatter of the next, the first and the last beyond it).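

In this assay, among the compounds shown here, methyl in place of hydrogen on this aromatic carbon, opposite the ring nitrogen, gives a number 12.8 percentage points higher from compound 3 to compound 4 (beyond the scatter), the first change at a single place in this set to go beyond the scatter. For the compounds shown here, this position therefore responds to even one added carbon, whereas the only earlier single-place step, in the amine ring, gave a number 2.8 percentage points lower from compound 2 to compound 3 (within the scatter) and stayed within the scatter. With the methyl present on both compounds, pyrrolidin-1-yl in place of thiomorpholin-4-yl gives a number 10.9 percentage points higher from compound 1 to compound 4 (beyond the scatter), so the amine ring can also matter, although this is a different swap from the earlier one, and nothing at hand explains either step.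

The compounds shown leave open whether the methyl would have the same effect with piperidin-1-yl or thiomorpholin-4-yl on the thiocarbonyl carbon, as compound 4 is the only methyl compound with a partner lacking it. They also leave open whether an ethyl, a methoxy or an amine on this carbon would follow the methyl, or whether a methyl on another carbon of the ring would do the same.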